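The compounds below may be only part of what the source reports. "The series", "measured", "known", "first", "only" and "open" are said of these compounds alone.

The compounds measured so far:

compound 1, `O=C(Nc1ccc(Cl)cc1)N1CCC[C@H]1c1nc(-c2cccc(F)c2)no1`: in an ADME assay on MCF-10A cells (Homo sapiens) for inhibition, with a stated time of 48 h (a higher number here means a weaker inhibitor, a lower number a stronger inhibitor), compound 1 gives > 50000 nM, which is a limit of the assay and not a number.
compound 2, `O=C(Nc1ccc(Cl)cc1)N1CCC[C@H]1c1nc(-c2cccc(Cl)c2)no1`: compound 2 gives > 50000 nM, again only a limit.
compound 3, `O=C(Nc1ccc(Cl)cc1)N1CCC[C@H]1c1nc(-c2ccc(F)cc2)no1`: compound 3 gives > 50000 nM, likewise a limit.

Compound 1 and compound 2 are separated by chloro in place of fluoro on an aromatic carbon. The resulting step, a step that the two limits leave unreadable from compound 1 to compound 2, has no readable size. The two cores of compound 1 and compound 3 differ by 4-fluorophenyl in place of 3-fluorophenyl on an aromatic carbon, and here too the step that the two limits leave unreadable from compound 1 to compound 3 cannot be sized. The same holds for a step that the two limits leave unreadable from compound 2 to compound 3. All three values rest at the limit of > 50000 nM in this assay, at which 3 of the 3 values shown sit, so nothing in this set tells how large any of these changes really is.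

Compound 4, `O=C(Nc1ccc(Cl)cc1)N1CCC[C@H]1c1nc(-c2ccc(Cl)cc2)no1`, is not yet measured. It differs from compound 3 by chloro in place of fluoro on an aromatic carbon. This is the same kind of change as that from compound 1 to compound 2, but its place is para to a large group, whereas the earlier change sat meta to a large group.

Compound 4 is expected to give 50000 nM, most probably reported once more as a limit rather than a number, with a plausible span from 20000 nM to 100000 nM. For compound 4 this amounts to an expected step of a number no higher from compound 3 to compound 4 (the limit leaves the size open), an expectation that rests on the matching step that the two limits leave unreadable from compound 1 to compound 2 being unreadable because both of its values sit at the limit of > 50000 nM in this assay, at which 3 of the 3 values shown sit.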

Compound 4, half-maximal inhibitory concentration: > 50000 nM
Compound 4: no number, only a limit; the forecaster's own chance of this, stated with the estimate: 85%; the middle value lies on the limit itself.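

In this assay compound 4 gives > 50000 nM, which is a limit of the assay and not a number. The steps linking compound 4 with compound 1, compound 2 and compound 3 therefore cannot be read, because all four compounds share one limit: the limit of > 50000 nM in this assay, at which 4 of the 4 values shown sit. The compounds shown leave open how large any of these changes really is and where each true value lies.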